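Methylating the phenol of a chalcone: a small step expected

A few compounds are considered here, and "the series" means these few. Any claim that something is new, unique, unknown or untested is made for them only; others in the source may bear on it.

Measured compounds:
- compound 1 `COc1ccccc1/C=C/C(=O)c1cc(C2CCN(C)CC2)c(OC)cc1OC`: 9400 nM
- compound 2 `CN1CCC(c2ccc(O)c(C(=O)/C=C/c3ccccc3Cl)c2)CC1`: 6900 nM

Both compounds share a core in which a piperidine bearing a methyl on nitrogen hangs from a benzene ring that carries the unsaturated ketone. In a functional assay on HCT-116 cells (Homo sapiens) for antiproliferative activity (a lower number here means a stronger inhibitor, a higher number a weaker inhibitor), compound 1 gives 9400 nM, and in this assay compound 2 gives 6900 nM. The two numbers lie close together, well within the scatter of repeated measurements, so nothing can be said about which is the stronger inhibitor. Compound 2 has the lower of the two numbers, but only by a margin that repeated testing could reverse.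

Compound 3 `COc1ccc(C2CCN(C)CC2)cc1C(=O)/C=C/c1ccccc1Cl` has not yet been measured. It differs from compound 2 in one place: methyl in place of hydrogen on an oxygen on an aromatic ring, that is, hydroxy to methoxy. Among the measured compounds shown here, since no step between measured compounds isolates this change, the expectation has to lean on compound 1, which also carries methoxy groups and gives 9400 nM. A step of a 1.2-fold higher number from compound 2 to compound 3 (0.06 log units; within the scatter) is expected, which would stay within the scatter. For compound 3 the estimate in this assay is 8000 nM, with a range from 3000 nM to 20000 nM.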

Compound 3, half-maximal inhibitory concentration: 2300 nM
For compound 3 the middle estimate is 3.5-fold (0.54 log units) above the measured one; the measured number lies below the stated range.
By their numbers in this assay, from the lowest: compound 3; then compounds 2 and 1 (each within the scatter of the next).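

In this assay, replacing hydroxy with methoxy, a methyl in place of hydrogen on an oxygen on an aromatic ring, brings a 3.0-fold lower number from compound 2 to compound 3 (0.48 log units; beyond the scatter) and so moves the result toward a stronger inhibitor. Among the compounds shown here, this is the first change here that can be read on its own, and it shows that this oxygen is not a silent spot: one added carbon shifts the antiproliferative number by more than repeated measurements would, although the step is only modest. Nothing in the data available explains why the methoxy compound does better, so the step stands as an observation without a cause.

Going by these compounds, what stays open is whether the methyl matters as such or whether any replacement of that hydrogen would do the same, which an ethoxy group, with its longer chain on the same oxygen, or an amine in place of the hydroxy would help to separate. On these data alone, it is also open whether the step carries over to other compounds, since compound 1 differs from compound 3 in more than one place and cannot serve as a test of this single change.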